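Fluorophenyl for Methylphenyl at the Outer Ring

The compounds below may be only part of what the source reports. "The series", "measured", "known", "first", "only" and "open" are said of these compounds alone.

Measured compounds in an assay on cells for activation of probable G-protein coupled receptor 34 (Mus musculus), with a stated time of 1 h; a lower number here means a smaller maximal response, a higher number a larger maximal response:
compound 1 `CCCCCCCCCCCOc1ccccc1CCC(=O)OCCCOP(=O)(O)OC[C@H](N)C(=O)O`: 0.04
compound 2 `N[C@@H](COP(=O)(O)OCCCOC(=O)CCc1ccccc1OCCCCCCOc1ccccc1)C(=O)O`: 0.071
compound 3 `Cc1cccc(Oc2cccc(COc3ccccc3CCC(=O)OCCCOP(=O)(O)OC[C@H](N)C(=O)O)c2)c1`: 0.29

Compound 3 stands highest of the three in this assay; compound 2 and compound 1 both lie beyond the scatter below it. Compound 4 `N[C@@H](COP(=O)(O)OCCCOC(=O)CCc1ccccc1OCc1cccc(Oc2ccc(F)cc2)c1)C(=O)O` is the next step from compound 3 (4-fluorophenyl in place of 3-methylphenyl on an oxygen on an aromatic ring). Among the measured compounds shown here, the only measured step, a number 0.031 higher from compound 1 to compound 2 (within the scatter), concerns a different part of the molecule and lay within the scatter, so nothing measured here speaks to an exchange of one outer ring for another. The step is therefore expected to stay within the scatter, a number 0.020 lower from compound 3 to compound 4 (within the scatter). For compound 4 an intrinsic activity of 0.27 is estimated, between 0.12 and 0.42.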

Compound 4, intrinsic activity: the largest response reached, as a fraction of the reference agonist's: 0.66
Estimate against measurement, compound 4: 0.39 below; the measured number lies above the stated range.
By their numbers in this assay, from the lowest: compounds 1 and 2 (each within the scatter of the next); then compound 3; then compound 4.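

In this assay, the outer ring on the oxygen proves to be a sensitive position: 4-fluorophenyl in place of 3-methylphenyl gives a number 0.37 higher from compound 3 to compound 4 (beyond the scatter). The two groups have the same heavy-atom count and the same counts of hydrogen-bond donors and acceptors, so those counts do not separate them. Nothing available explains the rise.

The exchange alters both the substituent and its printed ring number, and the compounds shown leave open which of the two accounts for the rise. A 4-methylphenyl or 3-fluorophenyl group at this position would separate the two.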